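The compounds below may be only part of what the source reports. "The series", "measured", "known", "first", "only" and "open" are said of these compounds alone.

In an ADME assay on TZM cells (Homo sapiens) for cytotoxicity, read by XTT assay, with a stated time of 4 days (a lower number here means that less compound is tolerated, a higher number that more compound is tolerated), compound 3 `Cc1cc(/C=C/C#N)cc(C)c1Oc1cc(Nc2ccc(C#N)cc2)c(N)cc1CO` gives 16300 nM, the higher of the two numbers available, though compound 2 `Cc1cc(/C=C/C#N)cc(C)c1Oc1cc(Nc2ccc(C#N)cc2)c(N)cc1C(F)(F)F`, at 15000 nM, sits within the scatter of it (a 1.1-fold higher number from compound 2 to compound 3 (0.04 log units; within the scatter)). For compound 1 `COC(=O)c1cc(N)c(Nc2ccc(C#N)cc2)cc1Oc1c(C)cc(/C=C/C#N)cc1C` this assay reports only a limit, > 22800 nM (the limit of > 22800 nM in this assay, at which 1 of the 3 values shown sits). Compound 4 `Cc1cc(/C=C/C#N)cc(C)c1Oc1cc(Nc2ccc(C#N)cc2)c(N)cc1C(=O)O` differs from compound 3 by carboxy in place of hydroxymethyl on an aromatic carbon. Within the data shown here, the steps that bear on this change are an at least 1.3-fold lower number from compound 1 to compound 3 (0.14 log units; that floor lies within the scatter) and a 1.1-fold higher number from compound 2 to compound 3 (0.04 log units; within the scatter), neither clearly beyond the scatter: swapping the group at this carbon has so far moved the number little. A step of similar size, a 1.1-fold higher number from compound 3 to compound 4 (0.04 log units; within the scatter), is therefore expected, with no direction beyond the scatter. Compound 4 is estimated at 18000 nM, between 9000 nM and 36000 nM.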

Compound 4, half-maximal cytotoxic concentration: 14900 nM
The estimate for compound 4 lay 1.2-fold (0.08 log units) above the measured number; low and high end bracket the measured number.
By their numbers in this assay, from the lowest: compounds 4, 2 and 3 (each within the scatter of the next). At a limit, above all of these: compound 1.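

In this assay, carboxy at this carbon, para to a (4-cyanophenyl)amino group, adds a third group that cannot be told apart from the others: a 1.1-fold lower number from compound 3 to compound 4 (0.04 log units; within the scatter), and a 1.0-fold lower number from compound 2 to compound 4 (0.00 log units; within the scatter). Hydrogen in place of methyl on the oxygen of compound 1 gives an at least 1.5-fold lower number from compound 1 to compound 4 (0.18 log units; that floor lies within the scatter). That step rests on a limit, not a number: the limit of > 22800 nM in this assay, at which 1 of the 4 values shown sits.

On these data alone, whether an amine, an amide or a longer chain at this carbon would move the number beyond the scatter stays open. So does the actual number for compound 1, and with it the true size of that step.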